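A few compounds are considered here, and "the series" means these few. Any claim that something is new, unique, unknown or untested is made for them only; others in the source may bear on it.

Going by the values given here, the three compounds measured so far share one core, seen in compound 1 `O=C(C1CCCCC1)N1CC(c2nc(-c3cccc(F)c3)no2)C1`, compound 2 `CC1CCC(C(=O)N2CC(c3nc(-c4cccc(Cl)c4)no3)C2)CC1` and compound 3 `Cc1cccc(S(=O)(=O)N2CC(c3nc(-c4cccc(Cl)c4)no3)C2)c1`, and differ only in the group attached to the amide-type nitrogen in the ring. In an assay on HEK293 cells for negative allosteric modulation of metabotropic glutamate receptor 5 (Homo sapiens), read by FLIPR (on this read-out higher numbers stand for weaker inhibition and lower numbers for stronger inhibition), compound 1 reaches only the limit of the assay, > 10000 nM. Compound 2 likewise gives only a limit in this assay, > 10000 nM. Compound 3, with a different group in the same place, gives 390 nM in this assay. Compound 2 thus stands at the weak end of what has been recorded, on the limit where two of the three values sit (the limit of > 10000 nM in this assay, at which 2 of the 3 values shown sit). Compound 4 `COC1CCCN(C(=O)N2CC(c3nc(-c4cccc(Cl)c4)no3)C2)C1` has not yet been measured. It differs from compound 2 in one place: 3-methoxypiperidin-1-yl in place of 4-methylcyclohexyl on a carbonyl carbon. Among the compounds with values here, no pair of measured compounds isolates this change, so no measured step can guide it. Both compound 1 and compound 2 carry a six-membered non-aromatic ring of carbon only on the carbonyl and both stop at the limit (the limit of > 10000 nM in this assay, at which 2 of the 3 values shown sit). Compound 4 keeps a six-membered non-aromatic ring on that carbonyl, so it is expected to stay weak, with a step no larger than the scatter expected a number no higher from compound 2 to compound 4 (the limit leaves the size open). Compound 4 is estimated to give about 10000 nM in this assay, expected between 2500 nM and 30000 nM.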

Compound 4, half-maximal inhibitory concentration: 1830 nM
Estimate against measurement, compound 4: 5.5-fold (0.74 log units) above; the whole stated range lies above it.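

In this assay, going by these compounds alone, 3-methoxypiperidin-1-yl in place of 4-methylcyclohexyl on a carbonyl carbon gives an at least 5.4-fold lower number from compound 2 to compound 4 (0.73 log units; beyond the scatter), the first step that can be read at this position. The result shows that a six-membered non-aromatic ring on this carbonyl does not in itself hold a compound at the limit, since the ring with 1 hetero atom and 1 hydrogen-bond acceptor gives a measured number where the ring of carbon only does not. The true size of the step stays open at its upper end because compound 2 gives only a limit, not a number: the limit of > 10000 nM in this assay, at which 2 of the 4 values shown sit.

The change brings in the ring nitrogen and the methoxy together and removes the methyl, so the compounds shown do not tell which of these carries the step, and a plain piperidin-1-yl or a 3-methoxycyclohexyl on the same carbonyl would be needed to separate them. On these data alone, it also remains open how a morpholin-4-yl, a methoxy moved elsewhere on the piperidine, or a longer ether chain in place of the methoxy would read out at this position.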